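The source may hold more compounds than are shown below. What is called first, only, known or untested is meant among the compounds shown, and "the series" means these compounds.

Measured so far:
compound 1 `Fc1cccc(F)c1Cn1c(-c2c(F)cccc2F)nc2c(Cl)cccc21` — 30.4 uM
compound 2 `CN(C)c1cccc2c1nc(-c1c(F)cccc1F)n2Cc1c(F)cccc1F` — > 100 uM, a limit of the assay
compound 3 `N=C(NO)c1cccc2c1nc(-c1c(F)cccc1F)n2Cc1c(F)cccc1F` — 23.1 uM

In a toxicity assay on CCRF-CEM cells (Homo sapiens) for cytotoxicity (on this read-out higher numbers stand for lower toxicity in this test and lower numbers for higher toxicity in this test), compound 1 stands highest of the two numbers given, with compound 3 nearest: a 1.3-fold lower number from compound 1 to compound 3 (0.12 log units; within the scatter). For compound 2 only a limit is reported, and the limit of > 100 uM in this assay, at which 1 of the 3 values shown sits, is where that value sits. Both swaps at the same aromatic carbon thus go toward an equal or higher number: an at least 3.2-fold higher number from compound 1 to compound 2 (0.51 log units; beyond the scatter), whereas replacing chloro with the four-atom group in compound 3 leaves the number within scatter.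

Compound 4 `CC(C)=CCc1cccc2c1nc(-c1c(F)cccc1F)n2Cc1c(F)cccc1F` is the next member. It differs from compound 1 as follows: 3-methylbut-2-en-1-yl in place of chloro on an aromatic carbon. Neither measured step replaces chloro with a hydrocarbon chain, so the bearing of the two steps is indirect. Both steps from compound 1 point to an unchanged or higher number on substitution at this carbon, and none to a lower one. For compound 4 the expectation is therefore a modest rise at most, quite possibly within scatter: a 1.5-fold higher number from compound 1 to compound 4 (0.17 log units; within the scatter). Compound 4 is estimated at 45 uM, with a range from 15 uM to 100 uM, and a fair chance that the assay returns only a limit.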

Compound 4, half-maximal toxic concentration: 28.3 uM
Compound 4: the middle estimate sits 1.6-fold (0.20 log units) above what was measured, within the range that was stated.
By their numbers in this assay, from the lowest: compounds 3, 4 and 1 (each within the scatter of the next). At a limit, above all of these: compound 2.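

In this assay, a hydrocarbon chain at this aromatic carbon gives a 1.1-fold lower number from compound 1 to compound 4 (0.03 log units; within the scatter) and so cannot be told apart from chloro, even though 3-methylbut-2-en-1-yl brings more heavy atoms than chloro does; the comparison with the four-atom group of compound 3 reads the same way, as a 1.2-fold higher number from compound 3 to compound 4 (0.09 log units; within the scatter) shows. Compounds 1, 3 and 4 therefore form one level at this position across three quite different groups, and dimethylamino is now the only change shown that separates from the rest, with an at least 3.5-fold lower number from compound 2 to compound 4 (0.54 log units; beyond the scatter) as the step from it to the chain. This separation rests on a single compound, and the entry for compound 2 is a limit, not a number: the limit of > 100 uM in this assay, at which 1 of the 4 values shown sits.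

From the compounds shown here alone, whether the separation belongs to amines in general remains open, and a primary amine, a methylamino group or a pyrrolidine at the same carbon would bear on that. Also open, going by these compounds, is whether a carboxylic acid or a longer, saturated chain would stay at the level of compounds 1, 3 and 4 or leave it.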